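Adding a second fluoro to compound 2

The compounds below may be only part of what the source reports. "The series", "measured", "known", "first", "only" and "open" are said of these compounds alone.

Measured so far:
- compound 1 `COC(=O)NC1=NC(c2ccccc2F)CN1`: 54 mg/kg
- compound 2 `COC(=O)NC1=NC(c2cccc(F)c2)CN1`: 70 mg/kg
- compound 3 `COC(=O)NC1=NC(c2cccc(Cl)c2)CN1`: 48 mg/kg

All three values come from a functional assay on the whole organism for antagonist activity, with Mus musculus as the target, in the maximal electroshock model; on this read-out higher numbers stand for an effect only at larger amounts of compound and lower numbers for an effect already at smaller amounts. Compound 2, at 70 mg/kg, lies within the scatter of both compound 1 and compound 3, so the three compounds are not yet separated on this read-out.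

Compound 4 `COC(=O)NC1=NC(c2cc(F)ccc2F)CN1` is still unmeasured. Its change from compound 2 is fluoro in place of hydrogen on an aromatic carbon.

For the measured compounds named here, the only measured step, a 1.5-fold lower number from compound 2 to compound 3 (0.16 log units; within the scatter), exchanges one substituent for another and stays within the scatter. Going by the values given here, no measured step adds a group to compound 2, so it bears only indirectly. Compound 1 has its single fluoro ortho to a large group, and compound 1 gives 54 mg/kg, which is within the scatter of compound 2.

No change beyond the scatter is therefore expected, and the estimated step is a 1.3-fold lower number from compound 2 to compound 4 (0.10 log units; within the scatter). Compound 4 is estimated at 55 mg/kg, with an expected range of 30 mg/kg to 100 mg/kg.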

Compound 4, dose for half-maximal effect: 49 mg/kg
Compound 4: middle estimate off by 1.1-fold (0.05 log units), on the high side; low and high end bracket the measured number.
By their numbers in this assay, from the lowest: compounds 3, 4, 1 and 2 (each within the scatter of the next).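

In this assay, fluoro in place of hydrogen on an aromatic carbon, ortho to a large group and para to a fluoro group, gives a 1.4-fold lower number from compound 2 to compound 4 (0.15 log units; within the scatter), so this place on the ring accepts a second fluoro without a change beyond the scatter. Read from the other single-fluoro compound, the second fluoro gives a 1.1-fold lower number from compound 1 to compound 4 (0.04 log units; within the scatter), and thus neither route to compound 4 separates it from its parent, which the earlier exchange of one halogen for another could not show. Nothing on hand explains these values.

The compounds shown carry only fluoro or chloro on the aromatic ring, and all remain unseparated on this read-out. On these data alone, whether a larger group at this place, such as methoxy, trifluoromethyl or an amine, would produce a step beyond the scatter remains open.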